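The compounds below may be only part of what the source reports. "The series", "measured", "known", "first", "only" and "open" are said of these compounds alone.

Measured in a functional assay on HepG2 cells (Homo sapiens) for antiproliferative activity, read by MTT assay, with a stated time of 48 h; a higher number here means a weaker inhibitor, a lower number a stronger inhibitor:
- compound 1 `Cc1ccccc1-n1nncc1CN1C(=O)C2(C(C#N)=C(N)Oc3c2c2nc4ccccc4nc2c2ccccc32)c2ccccc21`: > 50000 nM
- compound 2 `Cc1cccc(-n2nncc2CN2C(=O)C3(C(C#N)=C(N)Oc4c3c3nc5ccccc5nc3c3ccccc43)c3ccccc32)c1`: > 50000 nM
- compound 3 `N#CC1=C(N)Oc2c(c3nc4ccccc4nc3c3ccccc23)C12C(=O)N(Cc1cnnn1-c1ccccc1Br)c1ccccc12`: > 50000 nM

Compound 3 stands at the limit of > 50000 nM in this assay, at which 3 of the 3 values shown sit; its value is a limit, not a number. The value of compound 1 is likewise a limit. The value of compound 2 is likewise a limit. The steps a step that the two limits leave unreadable from compound 1 to compound 2, a step that the two limits leave unreadable from compound 1 to compound 3 and a step that the two limits leave unreadable from compound 2 to compound 3 are therefore unreadable in this assay: they only show that moving a methyl from the 2- to the 3-position of the phenyl on the aromatic nitrogen, or exchanging methyl for bromo, gave no reading within range.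

Compound 4 `N#CC1=C(N)Oc2c(c3nc4ccccc4nc3c3ccccc23)C12C(=O)N(Cc1cnnn1-c1cccc(Br)c1)c1ccccc12` differs from compound 3 by 3-bromophenyl in place of 2-bromophenyl on an aromatic nitrogen. The nearest measured step bearing on it is a step that the two limits leave unreadable from compound 1 to compound 2, which left both compounds at the limit. Compound 4 is therefore expected to remain at the limit as well, with an estimated value of 70000 nM (range 25000 nM to 250000 nM), an expected step that the limit leaves unreadable from compound 3 to compound 4 that cannot be distinguished from no change.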

Compound 4, half-maximal inhibitory concentration: > 50000 nM
Compound 4 ended at the assay's limit; the forecaster's own chance of this, stated with the estimate: 85%; the middle value does not contradict the limit.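

In this assay, compound 4 sits at a limit, as do compound 1, compound 2 and compound 3, so no step among them can be read: the limit of > 50000 nM in this assay, at which 4 of the 4 values shown sit.

The compounds shown leave open whether any of these phenyl changes alters antiproliferative activity.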